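The source may report more compounds than this note shows. Statements on the series, on what has been measured and on what is new or still open speak of the compounds shown alone.

Series notes on the shared core of compound 1 `COc1ccccc1-n1nc(C)c2c1NC(=O)[C@H](C)S[C@@H]2c1ccc(Oc2ccccc2)cc1` and compound 2 `Cc1ccc(-n2nc(C)c3c2NC(=O)[C@H](C)S[C@@H]3c2ccc(Oc3ccccc3)cc2)cc1`. In an assay on isolated protein for agonist activity at Bile acid receptor (Homo sapiens), read by AlphaScreen, with a stated time of 30 min (a lower number here means a smaller maximal response, a higher number a larger maximal response), compound 1 gives 37%, while compound 2 gives 11%. Going by the values given here, the one recorded step, a number 26 percentage points lower from compound 1 to compound 2 (beyond the scatter), came from putting 4-methylphenyl in place of 2-methoxyphenyl on an aromatic nitrogen. Compound 2 thus holds the lowest of the two numbers measured, and its nearest neighbour, compound 1, sits beyond the scatter above it.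

Compound 3 `Cc1cccc(-n2nc(C)c3c2NC(=O)[C@H](C)S[C@@H]3c2ccc(Oc3ccccc3)cc2)c1` differs from compound 2 by 3-methylphenyl in place of 4-methylphenyl on an aromatic nitrogen. Among the compounds with values here, no measured step rests on the same exchange, since the pair already recorded swaps 2-methoxyphenyl for 4-methylphenyl rather than shifting a methyl group within a phenyl ring. What can be said is that compound 1, with its 2-methoxyphenyl, gives 37%, and that compound 2, with 4-methylphenyl, gives 11%, so the aryl group on that nitrogen does matter in this assay. For compound 3 a small rise is expected, a number 9 percentage points higher from compound 2 to compound 3 (within the scatter), possibly within the scatter. The estimated efficacy of compound 3 is 20%, with a range from 5% to 40%.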

Compound 3, largest response reached (reported as efficacy), in percent of the reference or control that the assay uses: 22%
Compound 3: the middle estimate sits 2 percentage points below what was measured; the range from low to high includes it.
By their numbers in this assay, from the lowest: compound 2; then compound 3; then compound 1.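

In this assay, moving one methyl group on the phenyl ring gives a number 11 percentage points higher from compound 2 to compound 3 (beyond the scatter) even though 3-methylphenyl and 4-methylphenyl hold the same atoms, joined differently. The earlier step changed both the substituent and its place on the phenyl ring, whereas this one changes only the place, so placement alone is now shown to alter the maximal response for a group on this aromatic nitrogen. Exchanging 2-methoxyphenyl for 3-methylphenyl gives a number 15 percentage points lower from compound 1 to compound 3 (beyond the scatter) and so keeps the 2-methoxyphenyl compound on top of the three, but no measurement at hand accounts for either step.

The compounds shown leave open whether the higher number of compound 1 goes with methoxy as a substituent or with its place on the ring, a question that 2-methylphenyl and 4-methoxyphenyl groups on the same nitrogen would separate. Also open, on these data alone, is how the read-out behaves with unsubstituted phenyl or with a ring bearing an amine or a carboxylic acid, and whether the order seen here holds for any other group at this position.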